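This account rests on a few compounds, and the source may have more. Where it says the series, first, only, none or still open, it means among the compounds named here.

Measured compounds: compound 1 `COc1ccccc1COc1c(-c2ccccc2)oc2cc(O)cc(O)c2c1=O`, compound 2 `O=c1c(OCc2cccc(Cl)c2)c(-c2ccccc2)oc2cc(O)cc(O)c12`, compound 3 `Cc1cccc(COc2c(-c3ccccc3)oc3cc(O)cc(O)c3c2=O)c1`.

In an ADME assay on Huh-5-2 cells (Homo sapiens) for cytotoxicity, read by WST assay, with a stated time of 3 days (a higher number here means that more compound is tolerated, a lower number that less compound is tolerated), compound 1 gives 53000 nM, compound 2 gives 46000 nM and compound 3 gives 29000 nM. Compound 3 has the lowest of the three numbers, yet its steps to the others, a 1.8-fold lower number from compound 1 to compound 3 (0.26 log units; within the scatter) and a 1.6-fold lower number from compound 2 to compound 3 (0.20 log units; within the scatter), both sit within the scatter, so no order among them can be claimed. Compound 4 `O=c1c(OCc2ccc(Cl)cc2)c(-c2ccccc2)oc2cc(O)cc(O)c12` differs from compound 3 by 4-chlorophenyl in place of 3-methylphenyl on a saturated chain carbon bound to an oxygen on an aromatic ring. Among the measured compounds shown here, the steps that bear on this, a 1.2-fold lower number from compound 1 to compound 2 (0.06 log units; within the scatter), a 1.8-fold lower number from compound 1 to compound 3 (0.26 log units; within the scatter) and a 1.6-fold lower number from compound 2 to compound 3 (0.20 log units; within the scatter), all fall within the scatter; compound 2, which also carries a chloro group on this ring, is close to compound 3. Compound 4 is therefore expected to show a 1.4-fold higher number from compound 3 to compound 4 (0.14 log units; within the scatter), nothing beyond the scatter. The estimate for compound 4 in this assay is 40000 nM, ranging from 20000 nM to 80000 nM.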

Compound 4, half-maximal cytotoxic concentration: 36000 nM
Compound 4: middle estimate off by 1.1-fold (0.05 log units), on the high side; the range from low to high includes it.
By their numbers in this assay, from the lowest: compounds 3, 4, 2 and 1 (each within the scatter of the next).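

In this assay, 4-chlorophenyl in place of 3-chlorophenyl gives a 1.3-fold lower number from compound 2 to compound 4 (0.11 log units; within the scatter), so the place of the chloro group on this ring makes no readable difference. The comparisons with the other two groups agree, with a 1.2-fold higher number from compound 3 to compound 4 (0.09 log units; within the scatter) and a 1.5-fold lower number from compound 1 to compound 4 (0.17 log units; within the scatter), so all four substituted phenyl groups at this position lie within the scatter of one another. Nothing available explains these numbers. Still open, on these data alone, is whether an amine or a carboxylic acid on this ring, or a longer chain carrying it, would give a number beyond the scatter.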